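From 3-methylphenyl to 4-methylphenyl on a carbonyl carbon

This account rests on a few compounds, and the source may have more. Where it says the series, first, only, none or still open, it means among the compounds named here.

In an ADME assay on MT4 cells (Homo sapiens) for cytotoxicity, read by MTT assay (a higher number here means that more compound is tolerated, a lower number that less compound is tolerated), compound 1 (`Cc1ccccc1C(=O)N(C(=S)OCCN1C(=O)c2ccccc2C1=O)c1ccc(Cl)cc1`) gives 21000 nM while compound 2 (`Cc1cccc(C(=O)N(C(=S)OCCN2C(=O)c3ccccc3C2=O)c2ccc(Cl)cc2)c1`) gives 58000 nM and stands highest of the two. Compound 3 (`Cc1ccc(C(=O)N(C(=S)OCCN2C(=O)c3ccccc3C2=O)c2ccc(Cl)cc2)cc1`) carries 4-methylphenyl in place of 3-methylphenyl on a carbonyl carbon. Among the measured compounds shown here, the one measured step that bears on this is a 2.8-fold higher number from compound 1 to compound 2 (0.44 log units; beyond the scatter) and it sets no direction for the next change. Only a small change in either direction is therefore expected, and the estimated outcome is a 1.2-fold lower number from compound 2 to compound 3 (0.06 log units; within the scatter) as the likeliest case. For compound 3 the expected value is 50000 nM with an estimated range from 20000 nM to 110000 nM as its span.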

Compound 3, half-maximal cytotoxic concentration: > 100000 nM
Compound 3 gave a limit, no number (the forecaster's own chance of this, stated with the estimate: 15%); middle value at least 2.0-fold (0.30 log units) away from the limit.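

Compound 3 reads in this assay only as a limit, > 100000 nM, and not as a number. With 4-methylphenyl on the carbonyl carbon, the change from 3-methylphenyl gives an at least 1.7-fold higher number from compound 2 to compound 3 (0.23 log units; that floor lies within the scatter), so it cannot yet be told apart from the scatter, whereas the change from 2-methylphenyl gives an at least 4.7-fold higher number from compound 1 to compound 3 (0.67 log units; beyond the scatter). Thus 2-methylphenyl now stands apart from 4-methylphenyl as well as from 3-methylphenyl, and the reading for compound 3 rests at the edge of the assay: the limit of > 100000 nM in this assay, at which 1 of the 3 values shown sits.

Going by these compounds, how far compound 3 truly lies from compound 2 stays open. So does whether a methoxy group or a chlorine in place of the methyl would follow the same course.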